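A Methyl Added to the Phenoxy Ring

A few compounds are considered here, and "the series" means these few. Any claim that something is new, unique, unknown or untested is made for them only; others in the source may bear on it.

Of the compounds shown here, three with a shared core have been measured. Compound 1 `O=C1NC(=O)C(Cc2ccc(Cc3ccccc3)cc2)S1` gives 9280 nM in a functional assay for agonist activity at Free fatty acid receptor 1 (Homo sapiens), read by FLIPR, in the presence of a further agent that is not named here; on this read-out lower numbers stand for an effect already at smaller amounts and higher numbers for an effect only at larger amounts of compound. Compound 2 `O=C1NC(=O)C(Cc2ccc(Oc3ncc(Cl)cc3Cl)cc2)S1` gives 90 nM in this assay, and compound 3 `O=C1NC(=O)C(Cc2ccc(Oc3ccccc3)cc2)S1` gives 307 nM in this assay. Compound 3 therefore stands second highest of the three numbers, below compound 1 and above compound 2. Among the measured compounds shown here, the only single-change step, a 30-fold lower number from compound 1 to compound 3 (1.48 log units; beyond the scatter), exchanges one whole group for another and says little about a small addition. Compound 4 `Cc1cccc(Oc2ccc(CC3SC(=O)NC3=O)cc2)c1` differs from compound 3 by methyl in place of hydrogen on an aromatic carbon. For the measured compounds named here, no measured pair shows such an addition, so for compound 4 the step of a 1.2-fold lower number from compound 3 to compound 4 (0.09 log units; within the scatter) is expected to stay within the scatter. Compound 4 is thus estimated at 250 nM, between 90 nM and 700 nM.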

Compound 4, half-maximal effective concentration: 203 nM
Estimate against measurement, compound 4: 1.2-fold (0.09 log units) above; low and high end bracket the measured number.
By their numbers in this assay, from the lowest: compound 2; then compounds 4 and 3 (each within the scatter of the next); then compound 1.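

In this assay, methyl in place of hydrogen on an aromatic carbon, meta to a large group, gives a 1.5-fold lower number from compound 3 to compound 4 (0.18 log units; within the scatter), so this position takes the added methyl without a change that can be read. This small addition leaves the number far more settled than the whole-group exchange seen in a 30-fold lower number from compound 1 to compound 3 (1.48 log units; beyond the scatter). No measurement at hand explains this outcome.

Going by these compounds, whether the same position would accept an amine, a carboxylic acid, trifluoromethyl or a longer chain remains open.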